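From a chlorohexyl chain to a chlorophenyl ring

This account rests on a few compounds, and the source may have more. Where it says the series, first, only, none or still open, it means among the compounds named here.

Two compounds of the series carry numbers in an assay on LtK cells with ATP-sensitive inward rectifier potassium channel 11 (Homo sapiens) as the target; on this read-out higher numbers stand for an effect only at larger amounts of compound and lower numbers for an effect already at smaller amounts. Compound 1 `COCC(=O)Nc1c(C(O)(C(F)(F)F)C(F)(F)F)ccc2ccccc12` gives 213 nM. Going by the values given here, compound 2 `O=C(NCCCCCCCl)Nc1c(C(O)(C(F)(F)F)C(F)(F)F)ccc2ccccc12` gives 4840 nM, the highest of the two numbers; the only measured step, a 23-fold higher number from compound 1 to compound 2 (1.36 log units; beyond the scatter), separates it from compound 1. Compound 3 `O=C(Nc1ccc(Cl)cc1)Nc1c(C(O)(C(F)(F)F)C(F)(F)F)ccc2ccccc12` has no number yet. It differs from compound 2 by 4-chlorophenyl in place of 6-chlorohexyl on an amide-type nitrogen. Among the compounds with values here, no measured step covers an exchange on this amide-type nitrogen; the single recorded step, a 23-fold higher number from compound 1 to compound 2 (1.36 log units; beyond the scatter), concerns a different position and cannot show whether a chain-to-ring swap of the same size moves the number up or down. In the absence of a guiding step, only a small move is expected, a 1.6-fold lower number from compound 2 to compound 3 (0.21 log units; within the scatter), with a wide band around it. For compound 3 the estimate in this assay is 3000 nM, within a range from 600 nM to 15000 nM.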

Compound 3, half-maximal effective concentration: 276 nM
Estimate against measurement, compound 3: 11-fold (1.04 log units) above; the measured number lies below the stated range.
By their numbers in this assay, from the lowest: compounds 1 and 3 (each within the scatter of the next); then compound 2.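

On the amide-type nitrogen, the number depends strongly on which group is attached: 6-chlorohexyl and 4-chlorophenyl have the same heavy-atom count and both carry chlorine, yet this assay shows an 18-fold lower number from compound 2 to compound 3 (1.24 log units; beyond the scatter). The other new step, a 1.3-fold higher number from compound 1 to compound 3 (0.11 log units; within the scatter), shows that (4-chlorophenyl)amino and methoxymethyl on the carbonyl carbon cannot be told apart here, so a 23-fold higher number from compound 1 to compound 2 (1.36 log units; beyond the scatter) belongs to the (6-chlorohexyl)amino group and not to every amino group at this carbonyl carbon. No measurement at hand accounts for the difference between the chain and the ring.

Still open, on these data alone, is whether the aromatic ring or the removal of the chain matters more, which a cyclohexyl group or a shorter butyl chain on the same nitrogen could separate. As far as these compounds go, the part played by the chlorine also remains unknown, and a plain phenyl group would test it.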